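This account rests on a few compounds, and the source may have more. Where it says the series, first, only, none or still open, it means among the compounds named here.

Measured in a functional assay on A549 cells (Homo sapiens) for antiproliferative activity, read by MTT assay, with a stated time of 24 h; a higher number here means a weaker inhibitor, a lower number a stronger inhibitor:
- Compound 1 `Cc1cccc(NNC(=O)c2cccc(NS(=O)(=O)c3cnc(O)nc3O)c2)c1`: > 20000 nM
- Compound 2 `Cc1ccccc1NNC(=O)c1ccccc1NS(=O)(=O)c1cnc(O)nc1O`: > 20000 nM
- Compound 3 `O=C(NNC(=O)c1ccc(NS(=O)(=O)c2cnc(O)nc2O)cc1)c1ccc(F)cc1`: > 20000 nM

Compound 2 gives > 20000 nM, which is a limit of the assay and not a number. The two other entries are limits as well, so no order can be drawn among the three compounds.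

Compound 4 `Cc1ccccc1C(=O)NNC(=O)c1ccccc1NS(=O)(=O)c1cnc(O)nc1O` differs from compound 2 as follows: (2-methylphenyl)carbonyl in place of 2-methylphenyl on an amine nitrogen. In words, (2-methylphenyl)carbonyl stands in place of 2-methylphenyl on an amine nitrogen.

Among the measured compounds shown here, no measured step is available in this assay, so no size of change can be read from the series. The expectation rests on (the limit of > 20000 nM in this assay, at which 3 of the 3 values shown sit), and no change beyond the scatter is expected, in either direction. The expected step that the limit leaves unreadable from compound 2 to compound 4 is correspondingly small. Compound 4 is estimated at 25000 nM, with an expected range of 12000 nM to 60000 nM, and most likely it will again be reported only as a limit.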

Compound 4, half-maximal inhibitory concentration: 5450 nM
For compound 4 the middle estimate is 4.6-fold (0.66 log units) above the measured one, and the stated range ends above it.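

In this assay, the amine nitrogen proves responsive to substitution: (2-methylphenyl)carbonyl in place of 2-methylphenyl gives an at least 3.6-fold lower number from compound 2 to compound 4 (0.56 log units; beyond the scatter). Among the compounds shown here, compound 4, at 5450 nM, is the first entry to give a number and not a limit. The size of the step remains a bound only: the limit of > 20000 nM in this assay, at which 3 of the 4 values shown sit.

Going by these compounds, whether the step depends on the carbonyl alone or also on the attached 2-methylphenyl ring stays open. An acetyl or a methanesulfonyl group on the same nitrogen would bear on that question.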